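Removing One Methyl: What Solubility Is Expected for Compound 4

The compounds below may be only part of what the source reports. "The series", "measured", "known", "first", "only" and "open" are said of these compounds alone.

Compound 1 `Cc1cc(C(=O)Nc2cc(Oc3ccc4nc(NC(=O)C5CC5)nn4c3)ccc2C)n(C)n1` — 53 ug/mL
Compound 2 `Cc1cc(C(=O)Nc2cc(Oc3ccc4nc(NC(=O)C5CC5)cn4c3)ccc2C)n(C)n1` — 2.9 ug/mL
Compound 3 `Cc1cc(C(=O)Nc2cc(Oc3ccc4nc(NC(=O)C5CC5)sc4n3)ccc2C)n(C)n1` — 4.8 ug/mL

Of the compounds shown here, three have so far been measured in a physicochemical assay for solubility, measured as kinetic solubility, at pH 6.8; on this read-out lower numbers stand for lower solubility and higher numbers for higher solubility. Compound 1 gives 53 ug/mL, the highest of the three numbers. Compound 3 gives 4.8 ug/mL and compound 2 gives 2.9 ug/mL; both of these gaps to compound 1 lie beyond the scatter of repeated measurements. Compounds 2 and 3 differ from compound 1 in more than one place, so no single-point comparison can be drawn from them, and the differences between their cores are not pursued here.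

Compound 4 `Cc1ccc(Oc2ccc3nc(NC(=O)C4CC4)nn3c2)cc1NC(=O)c1ccnn1C` keeps the core of compound 1 and differs from it in one place only: hydrogen in place of methyl on an aromatic carbon. Among the compounds with values here, no pair of measured compounds shows a step of this kind, so the expectation for compound 4 rests on compound 1 alone and on the small size of the change. With only a methyl removed, the step from compound 1 to compound 4 is expected to be small, a 1.1-fold higher number from compound 1 to compound 4 (0.05 log units; within the scatter), likely none beyond the scatter, with no firm direction. Compound 4 is therefore expected to give about 60 ug/mL, in a range from 30 ug/mL to 120 ug/mL.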

Compound 4, solubility: > 80 ug/mL
Compound 4: no number, only a limit (the forecaster's own chance of this, stated with the estimate: 5%); middle value at least 1.3-fold (0.12 log units) from the limit.
By their numbers in this assay, from the lowest: compounds 2 and 3 (each within the scatter of the next); then compound 1. At a limit, above all of these: compound 4.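

For compound 4 the read-out in this assay is a limit and not a number: the limit of > 80 ug/mL in this assay, at which 1 of the 4 values shown sits.

Set against compound 1, the result reads as an at least 1.5-fold higher number from compound 1 to compound 4 (0.17 log units; that floor lies within the scatter), so the true size of the step cannot be told, only its floor. What it does show is new: on this aromatic carbon of the five-membered ring, going from 1,3-dimethyl-1H-pyrazol-5-yl to 1-methyl-1H-pyrazol-5-yl leaves the read-out no lower than that of compound 1, so the methyl is not needed for a number of that height.

The compounds shown hold only methyl and hydrogen at this place, so an ethyl chain, a methoxy group or an amine there remains untested in these data. Also open, from the compounds shown here alone, is whether the same removal of the methyl would give a similar result on the cores of compound 2 and compound 3.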